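Methyl for Trifluoromethyl on the Benzyl Triazole

The compounds below may be only part of what the source reports. "The series", "measured", "known", "first", "only" and "open" are said of these compounds alone.

Compound 1 `COc1ccc([C@@H]2CC(=O)c3c(O)cc(OCc4cn(Cc5ccccc5C(F)(F)F)nn4)cc3O2)cc1O` carries a 2-(trifluoromethyl)benzyl group. In a functional assay on RAW264.7 cells (Mus musculus) for inhibition, read by Griess assay, with stated times of 2 h and 24 h (on this read-out lower numbers stand for stronger inhibition and higher numbers for weaker inhibition), compound 1 gives 12500 nM, the second highest of three numbers. Compound 2 `COc1ccc([C@@H]2CC(=O)c3c(O)cc(OCc4cn(Cc5ccccc5F)nn4)cc3O2)cc1O` gives 7320 nM in this assay, and compound 3 `C=CCn1cc(COc2cc(O)c3c(c2)O[C@H](c2ccc(OC)c(O)c2)CC3=O)nn1` gives 13800 nM. Every step among them stays within the scatter: a 1.7-fold lower number from compound 1 to compound 2 (0.23 log units; within the scatter), a 1.1-fold higher number from compound 1 to compound 3 (0.04 log units; within the scatter) and a 1.9-fold higher number from compound 2 to compound 3 (0.28 log units; within the scatter). Compound 4 `COc1ccc([C@@H]2CC(=O)c3c(O)cc(OCc4cn(Cc5ccccc5C)nn4)cc3O2)cc1O` differs from compound 1 by methyl in place of trifluoromethyl on an aromatic carbon. The closest measured comparison, another swap on an aromatic carbon, is a 1.7-fold lower number from compound 1 to compound 2 (0.23 log units; within the scatter), which did not leave the scatter; a larger change, a 1.1-fold higher number from compound 1 to compound 3 (0.04 log units; within the scatter), also stayed within it. No step beyond the scatter is therefore expected in this assay. Compound 4 is estimated at 11000 nM, with a range from 5000 nM to 25000 nM. That estimate would mean a 1.1-fold lower number from compound 1 to compound 4 (0.06 log units; within the scatter).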

Compound 4, half-maximal inhibitory concentration: 13100 nM
Estimate against measurement, compound 4: 1.2-fold (0.08 log units) below; the range from low to high includes it.
By their numbers in this assay, from the lowest: compounds 2, 1, 4 and 3 (each within the scatter of the next).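

Methyl and trifluoromethyl are not told apart on this aromatic carbon in this assay (a 1.0-fold higher number from compound 1 to compound 4 (0.02 log units; within the scatter)), although methyl has three fewer heavy atoms. Methyl and fluoro are not told apart here either (a 1.8-fold higher number from compound 2 to compound 4 (0.25 log units; within the scatter)), so all three groups at this place lie within the scatter of one another. Putting 2-methylphenyl in place of vinyl also stays within it (a 1.1-fold lower number from compound 3 to compound 4 (0.02 log units; within the scatter)), and no supporting evidence bears on this flat result. Going by these compounds, whether an amine, a carboxylic acid or a longer chain at this place would leave the scatter remains open.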